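A few compounds are considered here, and "the series" means these few. Any claim that something is new, unique, unknown or untested is made for them only; others in the source may bear on it.

In a functional assay on MCF7 cells (Homo sapiens) for cytotoxicity, read by MTT assay, with a stated time of 72 h (a lower number here means a stronger inhibitor, a higher number a weaker inhibitor), compound 1 `CNC(=O)c1cc(Oc2ccc(NC(=O)c3nccc(-c4ccc(OC)cc4)n3)cc2F)ccn1` gives only a limit, > 100000 nM, and not a number. Compound 2 `CNC(=O)c1cc(Oc2ccc(NC(=O)c3cc(-c4ccc(Br)cc4)ncn3)cc2F)ccn1` also gives only a limit, > 100000 nM. Compound 1 therefore stands at the limit of > 100000 nM in this assay, at which 2 of the 3 values shown sit. Compound 3 `CNC(=O)c1cc(Oc2ccc(NC(=O)c3nccc(-c4ccc(OC)cc4)n3)cc2)ccn1` gives a number, 35200 nM.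

Compound 4 `CNC(=O)c1cc(Oc2ccc(NC(=O)c3nccc(-c4ccc(C)cc4)n3)cc2F)ccn1` has not yet been measured. It departs from compound 1 with methyl in place of methoxy on an aromatic carbon, para to a large group: methyl in place of methoxy on an aromatic carbon.

Within the data shown here, no measured step covers this change. Among the measured compounds shown here, the one step available, an at least 2.8-fold lower number from compound 1 to compound 3 (0.45 log units; beyond the scatter), lies beyond the scatter, but it comes with hydrogen in place of fluoro on an aromatic carbon. Compound 4 keeps that fluoro, as do compound 1 and compound 2, so no step beyond the scatter is expected here. The expected step is a number no higher from compound 1 to compound 4 (the limit leaves the size open). A limit rather than a number is the likelier report. For compound 4 the estimated value is 100000 nM, with an expected range from 40000 nM to 250000 nM.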

Compound 4, half-maximal inhibitory concentration: 69200 nM
Compound 4: middle estimate off by 1.4-fold (0.16 log units), on the high side, and the stated range covers the measured number.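

In this assay, compound 4 is the only fluoro-bearing compound shown that gives a number rather than a limit, so this position can now be read with the fluoro kept. The change from methoxy to methyl gives an at least 1.4-fold lower number from compound 1 to compound 4 (0.15 log units; that floor lies within the scatter), and since that floor lies within the scatter, the data do not establish a real shift, though the true step could be larger. Compound 1 gives only a limit, which leaves the upper size of the step unknown: the limit of > 100000 nM in this assay, at which 2 of the 4 values shown sit.

The compounds shown leave open how an amine, a hydroxyl or a chloro would read at this position. They also leave open whether hydrogen in place of fluoro would move the 4-methylphenyl compound as it moved the 4-methoxyphenyl one.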